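The source may hold more compounds than are shown below. What is called first, only, known or untested is meant among the compounds shown, and "the series" means these compounds.

Three compounds sharing one core were tested in a functional assay on HCT-116 cells (Homo sapiens), read by MTT assay, with a stated time of 72 h; a higher number here means a weaker inhibitor, a lower number a stronger inhibitor: compound 1 `Nc1nc2c(c(-c3ccco3)cn2[C@@H]2O[C@H](CO)[C@@H](O)[C@H]2O)c(=O)[nH]1`, compound 2 `Nc1nc2c(c(-c3ccoc3)cn2[C@@H]2O[C@H](CO)[C@@H](O)[C@H]2O)c(=O)[nH]1` and compound 3 `Nc1nc2c(c(-c3ccsc3)cn2[C@@H]2O[C@H](CO)[C@@H](O)[C@H]2O)c(=O)[nH]1`. Compound 3 gives only a limit, > 20000 nM. Compound 1 likewise gives only a limit, > 20000 nM. Compound 2 reads 14200 nM. The steps of an at least 1.4-fold lower number from compound 1 to compound 2 (0.14 log units; that floor lies within the scatter) and an at least 1.4-fold higher number from compound 2 to compound 3 (0.14 log units; that floor lies within the scatter) have floors within the scatter, while the step that the two limits leave unreadable from compound 1 to compound 3 cannot be read. Compound 4 `Nc1nc2c(c(-c3cc4ccccc4o3)cn2[C@@H]2O[C@H](CO)[C@@H](O)[C@H]2O)c(=O)[nH]1` carries 1-benzofuran-2-yl in place of thiophen-3-yl on an aromatic carbon, with 1-benzofuran-2-yl in place of thiophen-3-yl on an aromatic carbon. Going by the values given here, no measured step covers this exchange, so no step beyond the scatter is expected in this assay. The estimated change is an at least 1.1-fold lower number from compound 3 to compound 4 (0.04 log units; that floor lies within the scatter). Compound 4 is estimated at 18000 nM, with an expected range from 6000 nM to 50000 nM.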

Compound 4, half-maximal inhibitory concentration: > 100000 nM
Compound 4: a limit, no number (the forecaster's own chance of this, stated with the estimate: 60%); middle value at least 5.5-fold (0.74 log units) away from the limit.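

In this assay compound 4 gives only a limit, > 100000 nM. Setting 1-benzofuran-2-yl in place of furan-3-yl on this aromatic carbon gives an at least 7.0-fold higher number from compound 2 to compound 4 (0.84 log units; beyond the scatter), the first step in this set that lies beyond the scatter. The steps to compound 4 from compound 1 and from compound 3 cannot be read, since both sides of each are limits.

The compounds shown leave open how compound 4 ranks against compound 1 and compound 3. They also leave open whether an amine or a short alkyl chain on this aromatic carbon would give a measurable value in this assay.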